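Fluorine on the Pendant Phenyl: What Compound 4 May Give

A few compounds are considered here, and "the series" means these few. Any claim that something is new, unique, unknown or untested is made for them only; others in the source may bear on it.

Measured compounds:
- compound 1 `N#CC1=C(N)OC(c2c[nH]c3ccccc23)=C(C#N)C1c1ccc(Br)cc1`: 14.6%
- compound 2 `CN(C)c1ccc(C2C(C#N)=C(N)OC(c3c[nH]c4ccccc34)=C2C#N)cc1`: 18.5%
- compound 3 `Cc1ccccc1C1C(C#N)=C(N)OC(c2c[nH]c3ccccc23)=C1C#N`: 17.2%

All three share one core and differ only in the aryl group on a saturated ring carbon. In a functional assay, tested at 100 ug/mL (on this read-out higher numbers stand for a stronger effect at the one concentration tested and lower numbers for a weaker effect), compound 3 holds the second highest of the three numbers, yet both gaps lie within the scatter: a number 1.3 percentage points lower from compound 2 to compound 3 (within the scatter) and a number 2.6 percentage points higher from compound 1 to compound 3 (within the scatter). Compound 4 `N#CC1=C(N)OC(c2c[nH]c3ccccc23)=C(C#N)C1c1ccc(F)cc1` brings the change (4-fluorophenyl in place of 2-methylphenyl on a saturated ring carbon). Going by the values given here, the steps that bear on it, a number 2.6 percentage points higher from compound 1 to compound 3 (within the scatter) and a number 1.3 percentage points lower from compound 2 to compound 3 (within the scatter), show that swapping the aryl group moved the read-out only within the scatter, so no step beyond the scatter is expected: a number 1.2 percentage points lower from compound 3 to compound 4 (within the scatter). Compound 4 is therefore estimated at 16%, with a range from 9% to 23%.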

Compound 4, a percentage reported as activity, at one concentration (the size of the read-out at that concentration, not a potency): 16.2%
Compound 4: middle estimate off by 0.2 percentage points, on the low side; the measured number falls inside the stated range.
By their numbers in this assay, from the lowest: compounds 1, 4, 3 and 2 (each within the scatter of the next).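

Fluoro on the phenyl ring adds a third substituent at this aromatic carbon, and in this assay the swaps remain small: a number 1.6 percentage points higher from compound 1 to compound 4 (within the scatter), a number 2.3 percentage points lower from compound 2 to compound 4 (within the scatter), and a number 1 percentage points lower from compound 3 to compound 4 (within the scatter). All four aryl groups on the saturated ring carbon therefore cannot be told apart on this read-out. No measurement at hand explains this.

From the compounds shown here alone, it remains open whether a carboxylic acid or an aminomethyl group on the phenyl ring, or a longer chain in place of the ring, would move the read-out beyond the scatter.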